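The compounds below may be only part of what the source reports. "The series", "measured", "known", "first", "only" and "open" are said of these compounds alone.

Measured so far:
compound 1 `COc1ccc(-c2nc3ccccn3c2C(=O)/C=C\Nc2ccc3cc[nH]c3c2)cc1`
compound 2 `COc1ccc(-c2nc3ccccn3c2C(=O)/C=C\Nc2cnc3ccccc3c2)cc1`
compound 3 `O=C(/C=C\Nc1ccc2cc[nH]c2c1)c1c(-c2ccc(Cl)cc2)nc2ccccn12`

In a functional assay on MCF7 cells (Homo sapiens) for cytotoxicity, read by MTT assay, with a stated time of 48 h (on this read-out lower numbers stand for stronger inhibition and higher numbers for weaker inhibition), compound 1 gives 19400 nM, compound 2 gives 15000 nM and compound 3 gives 9600 nM. Compound 4 `O=C(/C=C\Nc1cnc2ccccc2c1)c1c(-c2ccc(Cl)cc2)nc2ccccn12` has not been measured yet. Compound 2 differs from compound 1 by quinolin-3-yl in place of 1H-indol-6-yl on an amine nitrogen, and that change made a step of a 1.3-fold lower number from compound 1 to compound 2 (0.11 log units; within the scatter). Compound 4 differs from compound 3 in the same way, at the same place: quinolin-3-yl in place of 1H-indol-6-yl on an amine nitrogen. The two cores themselves differ by chloro in place of methoxy on an aromatic carbon, which made a step of a 2.0-fold lower number from compound 1 to compound 3 (0.31 log units; beyond the scatter). Because the earlier step of a 1.3-fold lower number from compound 1 to compound 2 (0.11 log units; within the scatter) stayed within the scatter, the step from compound 3 to compound 4 in this assay is expected to be similarly small, about a 1.3-fold lower number from compound 3 to compound 4 (0.11 log units; within the scatter). Compound 4 is therefore estimated at 7500 nM, with a likely range from 3500 nM to 16000 nM.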

Compound 4, half-maximal inhibitory concentration: 18900 nM
Beside the measured number, compound 4's estimate is 2.5-fold (0.40 log units) below it, and the stated range ends below it.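

In this assay, quinolin-3-yl in place of 1H-indol-6-yl gives a 2.0-fold higher number from compound 3 to compound 4 (0.29 log units; within the scatter), and this step does not differ measurably from the same change on the other core: the same change on two cores in this assay, a 1.3-fold lower number (0.11 log units; within the scatter) from compound 1 to compound 2 and a 2.0-fold higher number (0.29 log units; within the scatter) from compound 3 to compound 4, 2.5-fold (0.41 log units) apart, within the scatter of two such steps

Chloro in place of methoxy reads the same way, with a 1.3-fold higher number from compound 2 to compound 4 (0.10 log units; within the scatter): the same change on two cores in this assay, a 2.0-fold lower number (0.31 log units; beyond the scatter) from compound 1 to compound 3 and a 1.3-fold higher number (0.10 log units; within the scatter) from compound 2 to compound 4, 2.5-fold (0.41 log units) apart, within the scatter of two such steps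

Going by these compounds alone, with only two pairs for each change, the data show no real dependence on the core, but they do not prove that either step keeps its size when carried to another core.

The compounds shown leave open what a simpler group, such as a pyridinyl or a phenyl, would do on the amine nitrogen. They also leave open whether fluoro or methyl on that aromatic carbon would follow chloro.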